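The source may hold more compounds than are shown below. What is called first, only, known or untested is meant among the compounds shown, and "the series" means these compounds.

Working notes on a series that shares one core and varies only in the saturated chain on oxygen. In a functional assay, with stated times of 30 s and 6 min, in the presence of a further agent that is not named here (on this read-out lower numbers stand for stronger inhibition and higher numbers for weaker inhibition), compound 1 (`CCCCCCCCOc1cc(OC)ccc1C(C)=O`) gives 21200000 nM, compound 2 (`CCCCCCCCCCCCOc1cc(OC)ccc1C(C)=O`) gives 28500000 nM and compound 3 (`CCCCCCCCCCCCCCOc1cc(OC)ccc1C(C)=O`) gives 35900000 nM. Compound 3 stands within the scatter of both other compounds, so the three numbers support no ranking.

The next member is compound 4 (`CCCCCCCCCCCCCCCCOc1cc(OC)ccc1C(C)=O`). The change is ethyl in place of hydrogen on a saturated chain carbon, ten or more bonds along the chain from an oxygen on an aromatic ring.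

Among the measured compounds shown here, the closest precedent is a 1.3-fold higher number from compound 2 to compound 3 (0.10 log units; within the scatter), which is the same ethyl change at the same kind of place. Two larger chain changes also bear on it: butyl gives a 1.3-fold higher number from compound 1 to compound 2 (0.13 log units; within the scatter) and hexyl gives a 1.7-fold higher number from compound 1 to compound 3 (0.23 log units; within the scatter). For the measured compounds named here, none of these three steps leaves the scatter, so no step beyond the scatter is expected in this assay, and the estimate simply carries over the size of the closest precedent.

The expected step is a 1.2-fold higher number from compound 3 to compound 4 (0.08 log units; within the scatter). For compound 4 the estimated value is 43000000 nM, with an expected range from 24000000 nM to 75000000 nM.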

Compound 4, half-maximal inhibitory concentration: 39400000 nM
Estimate against measurement, compound 4: 1.1-fold (0.04 log units) above; low and high end bracket the measured number.
By their numbers in this assay, from the lowest: compounds 1, 2, 3 and 4 (each within the scatter of the next).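

In this assay, a second ethyl change at this place again stays within the scatter (a 1.1-fold higher number from compound 3 to compound 4 (0.04 log units; within the scatter)), and so does the butyl change read across the same stretch of chain (a 1.4-fold higher number from compound 2 to compound 4 (0.14 log units; within the scatter)). The octyl change, the widest span the series now offers, also stays within the scatter (a 1.9-fold higher number from compound 1 to compound 4 (0.27 log units; within the scatter)), so neither single steps nor the full span separate any of the four compounds, and the chain lengths shown give no ranking on this read-out. No accompanying measurement bears on why the numbers stay this close.

As far as these compounds go, whether a chain longer than that of compound 4, a chain shorter than that of compound 1, or an amine or a carboxylic acid on a saturated chain carbon would give a step beyond the scatter remains open. All four numbers come from one read-out on the shared core, so they cannot tell whether the same chain changes would behave alike in another assay or on another core.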